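The source may report more compounds than this note shows. Statements on the series, on what has been measured and on what is new or still open speak of the compounds shown alone.

Measured so far in an ADME assay on RAW264.7 cells (Mus musculus) for cytotoxicity, read by MTT assay; on this read-out lower numbers stand for stronger inhibition and higher numbers for weaker inhibition:

- compound 1 (`O=C(/C=C/C=C/c1ccccc1)c1cc(Br)ccc1O`), result ("not determined" (no result reported))
- compound 2 (`Cc1cc(C(=O)/C=C/C=C/c2ccccc2)c(C)o1`), result (> 100000 nM)
- compound 3 (`COc1ccc(/C=C/C=C/C(=O)c2ccc(OC)cc2)cc1`), result ("not determined" (no result reported))

Compound 2 reads > 100000 nM as a limit of the assay and not a number. Compound 1 and compound 3 supply no number, so the position of the series rests on the limit of > 100000 nM in this assay, at which 1 of the 3 values shown sits, and no single measured value exists yet. Compound 2 therefore offers a limit as its only reference point, not a figure from which a step can be counted.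

The next entry is compound 4 (`COc1ccc(/C=C/C=C/C(=O)c2cc(C)oc2C)cc1`). It differs from compound 2 by one change: methoxy in place of hydrogen on an aromatic carbon, on a six-membered aromatic ring of carbon only, para to a large group (methoxy in place of hydrogen on an aromatic carbon). Compound 3 also carries methoxy but gives no number for comparison.

Within the data shown here, no measured pair sizes such a change. The expectation in this assay is therefore of no shift beyond the scatter in either direction, and the estimated step of a number no higher from compound 2 to compound 4 (the limit leaves the size open) is expected to be small. Compound 4 is estimated at 100000 nM with an expected range of 40000 nM to 250000 nM in this assay.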

Compound 4, half-maximal inhibitory concentration: > 100000 nM
Compound 4 was reported as a limit; the forecaster's own chance of this, stated with the estimate: 70%; the middle value lies on the limit itself.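

In this assay, among these compounds, compound 2 and compound 4 both read as limits and not as numbers, so no step for methoxy in place of hydrogen on an aromatic carbon can be read between them. The compounds shown leave open what single value any member of the series would give in this assay, and so how large that change is.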